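The compounds below may be only part of what the source reports. "The series", "measured", "known", "first", "only" and "open" are said of these compounds alone.

Measured compounds in a functional assay on KB cells (Homo sapiens) for antiproliferative activity, read by sulforhodamine B assay, with a stated time of 3 days; a lower number here means a stronger inhibitor of growth, a higher number a weaker inhibitor of growth:
compound 1 `CN(C)CC(=O)Nc1cccc(Nc2ncc(F)c(Nc3ccc(F)cc3)n2)c1`, 1260 nM
compound 2 `O=C(Nc1cccc(Nc2ncc(F)c(Nc3ccc(F)cc3)n2)c1)c1ccncc1`, 5280 nM
compound 3 `COCC(=O)Nc1cccc(Nc2ncc(F)c(Nc3ccc(F)cc3)n2)c1`, 6250 nM

Compound 3 carries the highest number of the three; compound 2 sits within the scatter of it, while compound 1 lies further off, as a 5.0-fold higher number from compound 1 to compound 3 (0.70 log units; beyond the scatter) shows. Compound 4 `O=C(Nc1cccc(Nc2ncc(F)c(Nc3ccc(F)cc3)n2)c1)c1cccc([N+](=O)[O-])c1` differs from compound 3 by 3-nitrophenyl in place of methoxymethyl on a carbonyl carbon. The step that bears on this is a 1.2-fold higher number from compound 2 to compound 3 (0.07 log units; within the scatter), where an aromatic group on the carbonyl carbon gave way to methoxymethyl without a step beyond the scatter; the reverse move, to 3-nitrophenyl, is therefore expected to give no step beyond the scatter in this assay either, a 1.1-fold lower number from compound 3 to compound 4 (0.06 log units; within the scatter). Compound 4 is estimated at 5500 nM, with a range from 2000 nM to 15000 nM.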

Compound 4, concentration for 50% growth inhibition: 15100 nM
Compound 4: the middle estimate sits 2.7-fold (0.44 log units) below what was measured; measured number above the stated range.
By their numbers in this assay, from the lowest: compound 1; then compounds 2 and 3 (each within the scatter of the next); then compound 4.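

In this assay, aromatic groups on the carbonyl carbon do not all read alike: 3-nitrophenyl gives a weaker result than pyridin-4-yl (a 2.9-fold higher number from compound 2 to compound 4 (0.46 log units; beyond the scatter)). It also falls short of methoxymethyl (a 2.4-fold higher number from compound 3 to compound 4 (0.38 log units; beyond the scatter)), so the parity between compound 2 and compound 3 does not extend to compound 4, and the distance from the (dimethylamino)methyl group grows (a 12-fold higher number from compound 1 to compound 4 (1.08 log units; beyond the scatter)). No measurement here accounts for these steps.

A plain phenyl on the carbonyl carbon would help show whether the step follows the nitro group or the ring. From the compounds shown here alone, whether a longer chain ending in dimethylamino keeps the lower number of compound 1 remains open.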